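Swapping the aryl group on the shared core

This account rests on a few compounds, and the source may have more. Where it says the series, first, only, none or still open, it means among the compounds named here.

Measured compounds:
Compound 1, `Cc1ccnc(NC(c2ccc([N+](=O)[O-])cc2)c2ccc3cccnc3c2O)c1`: in an assay for inhibition of protein disulfide-isomerase (Homo sapiens), with a stated time of 1 h (a higher number here means a weaker inhibitor, a lower number a stronger inhibitor), compound 1 gives 530 nM.
Compound 2, `Cc1ccnc(NC(c2ccccc2C)c2ccc3cccnc3c2O)c1`: compound 2 gives > 40000 nM, which is a limit of the assay and not a number.
Compound 3, `Cc1ccnc(NC(c2ccc3cccnc3c2O)c2c(Cl)cccc2Cl)c1`: compound 3 gives > 40000 nM, again a limit rather than a number.

Compound 3 therefore stands at the upper edge of what this assay reports, as the limit of > 40000 nM in this assay, at which 2 of the 3 values shown sit, records. Compound 4, `Cc1ccnc(NC(c2ccc(C(F)(F)F)cc2)c2ccc3cccnc3c2O)c1`, differs from compound 3 in a single place: 4-(trifluoromethyl)phenyl in place of 2,6-dichlorophenyl on a saturated chain carbon bound to an aromatic carbon and a nitrogen on an aromatic ring. Within the data shown here, two measured steps bear on this change. an at least 75-fold higher number from compound 1 to compound 3 (1.87 log units; beyond the scatter) and an at least 75-fold higher number from compound 1 to compound 2 (1.87 log units; beyond the scatter) both show that replacing 4-nitrophenyl with 2,6-dichlorophenyl or 2-methylphenyl moved the number from a measurable value to the limit, while a step that the two limits leave unreadable from compound 2 to compound 3 cannot be read. Compound 4 carries 4-(trifluoromethyl)phenyl, a group named in the same way as the 4-nitrophenyl of compound 1 rather than like the groups of compounds 2 and 3. A large step back down in this assay is therefore expected, although a trifluoromethyl group is not a nitro group and the return may be incomplete. Compound 4 is expected to give 1500 nM, plausibly between 400 nM and 15000 nM. The estimated step is an at least 26-fold lower number from compound 3 to compound 4 (1.42 log units; beyond the scatter).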

Compound 4, half-maximal inhibitory concentration: 26500 nM
Compound 4: middle estimate off by 18-fold (1.25 log units), on the low side; the whole stated range lies below it.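

In this assay, trifluoromethyl in place of nitro on an aromatic carbon gives a 50-fold higher number from compound 1 to compound 4 (1.70 log units; beyond the scatter), so a 4-substituted phenyl alone does not reproduce the result of compound 1, and here the nitro group cannot simply be exchanged for trifluoromethyl. Compound 4 returns a number where two other aryl groups reached the limit, but an at least 1.5-fold lower number from compound 3 to compound 4 (0.17 log units; that floor lies within the scatter) and an at least 1.5-fold lower number from compound 2 to compound 4 (0.17 log units; that floor lies within the scatter) have floors within the scatter, so it cannot be called a stronger inhibitor than either. Compounds 2 and 3 remain limits rather than numbers, and the true size of these steps cannot be read: the limit of > 40000 nM in this assay, at which 2 of the 4 values shown sit.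

A phenyl carrying a nitrile, a carboxylic acid or an amine in place of nitro would show whether compound 1 stands alone among such groups. From the compounds shown here alone, whether the large step from nitro to trifluoromethyl would hold on a core other than the shared one also remains open.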